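This account rests on a few compounds, and the source may have more. Where it says the series, first, only, none or still open, it means among the compounds named here.

Working notes on the series. In a functional assay (aorta) with Rattus norvegicus as the target (a higher number here means that more compound is needed for the effect, a lower number that less compound is needed), compound 1 (`COc1ccc(-c2nc(CN)sc2-c2ccc(OC)cc2)cc1`) gives 7.7 uM and compound 2 (`COc1ccc(-c2nc(CNC(=O)CSC)sc2-c2ccc(OC)cc2)cc1`) gives 6 uM. These two values lie within the scatter of each other, so compound 2 stands level with compound 1 on the numbers available.

Compound 3 (`COc1ccc(-c2nc(CNC(=O)C3=NNC(=O)CC3)sc2-c2ccc(OC)cc2)cc1`) differs from compound 2 by one change: a group of 7 heavy atoms (4 carbon, 2 nitrogen, 1 oxygen; one six-membered non-aromatic ring with 2 hetero atoms) in place of a group of 3 heavy atoms (2 carbon, 1 sulfur; no ring), on a carbonyl carbon. The (methylsulfanyl)methyl group leaves, and a group with one six-membered non-aromatic ring with 2 hetero atoms enters on the same carbonyl carbon.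

Among the measured compounds shown here, only one measured step bears on this: a 1.3-fold lower number from compound 1 to compound 2 (0.11 log units; within the scatter). That step shows that acylating the amine nitrogen left the number in this assay within the scatter. For the measured compounds named here, it does not test a ring at this carbonyl carbon, and no measured compound carries one, so the evidence is thin. No step beyond the scatter is expected in either direction, though the range is kept wide. The estimated step is no change at the digits printed from compound 2 to compound 3 (within the scatter). For compound 3, the expected value is 6 uM, with an estimated range from 2.5 uM to 15 uM.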

Compound 3, concentration for half-maximal effect: 7.3 uM
Beside the measured number, compound 3's estimate is 1.2-fold (0.09 log units) below it; low and high end bracket the measured number.
By their numbers in this assay, from the lowest: compounds 2, 3 and 1 (each within the scatter of the next).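

In this assay, the group with one six-membered non-aromatic ring with 2 hetero atoms on the carbonyl carbon, in place of (methylsulfanyl)methyl, gives a 1.2-fold higher number from compound 2 to compound 3 (0.09 log units; within the scatter) and so shows that a ring with more hetero atoms and a hydrogen-bond donor can stand at this carbonyl carbon without a step beyond the scatter. The comparison with the free amine reads a 1.1-fold lower number from compound 1 to compound 3 (0.02 log units; within the scatter) and adds a second acyl group on the amine nitrogen, of a different size and with a ring, that stays within the scatter of compound 1, so the flat picture in this assay now rests on two unlike groups rather than one. No measurement in hand gives a reason for this flat picture.

Still open, from the compounds shown here alone, is whether any group on this carbonyl carbon moves the number beyond the scatter, for example a carboxylic acid, a terminal amine, a phenyl ring or a longer chain in place of the groups of compound 2 and compound 3. Also open, going by these compounds, is whether the shared core, rather than this amide side, sets the number, which these three compounds cannot separate.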